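Dropping a methyl from the most weakly active analogue

The source may report more compounds than this note shows. Statements on the series, on what has been measured and on what is new or still open speak of the compounds shown alone.

Of the compounds shown here, three sharing one core have been tested in a functional assay on cells (Cancer cell lines, Homo sapiens) for cytotoxicity, with a stated time of 48 h; on this read-out lower numbers stand for stronger inhibition of growth and higher numbers for weaker inhibition of growth. Compound 1 `COc1cc2c(/C=C3/C(=O)Nc4ccc(O)cc43)c(Cl)n(Cc3cc(OC)c(OC)c(OC)c3)c2cc1C` gives 2040 nM, and compound 2 `COc1cc2c(/C=C3/C(=O)Nc4ccc(Cl)cc43)c(Cl)n(Cc3cc(OC)c(OC)c(OC)c3)c2cc1C` gives 2340 nM. Among the measured compounds shown here, the only single-point step between measured compounds, a 1.1-fold higher number from compound 1 to compound 2 (0.06 log units; within the scatter), falls within the scatter. Compound 3 `COc1cc2c(cc1C)NC(=O)/C2=C/c1c(Cl)n(Cc2cc(OC)c(OC)c(OC)c2)c2cc(C)c(OC)cc12` gives 49000 nM, the highest number of the three, well beyond the scatter from both compound 1 and compound 2.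

Compound 4 `COc1ccc2c(c1)/C(=C\c1c(Cl)n(Cc3cc(OC)c(OC)c(OC)c3)c3cc(C)c(OC)cc13)C(=O)N2` differs from compound 3 by a single change: hydrogen in place of methyl on an aromatic carbon. For the measured compounds named here, no measured step touches this position, and the one step available swaps chloro for hydroxy elsewhere, so it offers no direct guide. Compound 1 and compound 2, each carrying one substituent on the ring that bears the amide, sit far below compound 3, which carries two. Removing the methyl moves compound 4 toward that simpler pattern, so a modestly lower number is expected, though the retained methoxy leaves the outcome uncertain. The expected step is a 2.0-fold lower number from compound 3 to compound 4 (0.29 log units; within the scatter). Compound 4 is estimated at 25000 nM, between 8000 nM and 80000 nM.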

Compound 4, concentration for 50% growth inhibition: 16200 nM
Estimate against measurement, compound 4: 1.5-fold (0.19 log units) above, and the stated range covers the measured number.
By their numbers in this assay, from the lowest: compounds 1 and 2 (each within the scatter of the next); then compound 4; then compound 3.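

In this assay the methyl on the aromatic carbon ortho to a methoxy group proves to matter, with a 3.0-fold lower number from compound 3 to compound 4 (0.48 log units; beyond the scatter) as the result of replacing it by hydrogen, yet compound 4 still stays well above compounds 1 and 2. The neighbouring methoxy also counts: chloro and hydroxy gave numbers within the scatter of each other, but a 6.9-fold higher number from compound 2 to compound 4 (0.84 log units; beyond the scatter) comes with methoxy in place of chloro and a 7.9-fold higher number from compound 1 to compound 4 (0.90 log units; beyond the scatter) with methyl added on the hydroxy oxygen. No measurement shown here explains either change.

As far as these compounds go, whether removing the methyl would have the same effect without the methoxy remains open. So does how an ethyl in place of that methyl, or an amine in place of the methoxy, would compare in this series.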